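This account rests on a few compounds, and the source may have more. Where it says the series, first, only, none or still open, it means among the compounds named here.

Compound 1, `Nc1nc(Cl)c2ncn(COCCO)c2n1`: 69 ug/mL
Compound 2, `Nc1nc2c(nc(Br)n2COCCO)c(=O)[nH]1`: 355 ug/mL

Two compounds were measured in a functional assay on L1210 cells (Mus musculus) for inhibition; on this read-out lower numbers stand for stronger inhibition and higher numbers for weaker inhibition. Compound 1 gives 69 ug/mL, and compound 2 gives 355 ug/mL, the higher of the two numbers and therefore the weaker inhibition of the pair; the gap between them is beyond the usual scatter of the measurement, so compound 2 is the less potent of the two on this read-out. No pair of these compounds differs in only one place, so their two values are all that can be said of them together.

The next compound, compound 3, `CNc1nc2c(=O)[nH]c(N)nc2n1COCCO`, shares the core of compound 2 and differs from it in one place: methylamino in place of bromo on an aromatic carbon. Within the data shown here, there is no measured step that shows what this exchange does, and nothing else here to lean on. The step of a 1.2-fold lower number from compound 2 to compound 3 (0.07 log units; within the scatter) is expected to be small and not beyond the scatter, with no clear direction. Compound 3 is therefore estimated at 300 ug/mL in this assay, with a range from 100 ug/mL to 900 ug/mL.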

Compound 3, concentration for 50% inhibition: > 500 ug/mL
Compound 3 was reported as a limit; the forecaster's own chance of this, stated with the estimate: 30%; middle value at least 1.6-fold (0.22 log units) from the limit.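

In this assay compound 3 is reported only as a limit of the assay, > 500 ug/mL, and not as a number. Methylamino in place of bromo on this aromatic carbon, between two ring nitrogen atoms and next to the ring atom that bears the (2-hydroxyethoxy)methyl group, gives an at least 1.4-fold higher number from compound 2 to compound 3 (0.14 log units; that floor lies within the scatter), the first step at this position that can be read at all, so the exchange brings no gain in inhibition that this read-out can show. The floor of that step does not separate compound 3 from compound 2 beyond the scatter, and how weak compound 3 really is cannot be told, as its value sits at the edge of what the assay reports: the limit of > 500 ug/mL in this assay, at which 1 of the 3 values shown sits.

From the compounds shown here alone, it remains open whether the true gap between compound 2 and compound 3 is large or small, and the limit gives no size for it. Also open, going by these compounds, is whether a plain amine, or a longer chain on the nitrogen of the methylamino group, would move the number on this carbon in either direction.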